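Adding a second thiophene ester: working notes

The compounds below may be only part of what the source reports. "The series", "measured", "known", "first", "only" and "open" are said of these compounds alone.

Values in an ADME assay on HepG2 2.2.15 cells (Homo sapiens) for cytotoxicity, read by MTT assay; a higher number here means that more compound is tolerated, a lower number that less compound is tolerated:
- compound 1 `C=C1CC[C@@H]2[C@](C)(COC(=O)c3ccc(OC)nc3)[C@H](O)CC[C@@]2(C)[C@@H]1/C=C/C1=CCOC1=O`: 1340000 nM
- compound 2 `C=C1CC[C@@H]2[C@](C)(COC(=O)c3cccs3)[C@H](O)CC[C@@]2(C)[C@@H]1/C=C/C1=CCOC1=O`: 557000 nM

Compound 2 holds the lower of the two numbers in this assay. Compound 3 `C=C1CC[C@@H]2[C@](C)(COC(=O)c3cccs3)[C@H](OC(=O)c3cccs3)CC[C@@]2(C)[C@@H]1/C=C/C1=CCOC1=O` differs from it by (thiophen-2-yl)carbonyl in place of hydrogen on an oxygen on a saturated carbon. Among the compounds with values here, the only measured step, a 2.4-fold lower number from compound 1 to compound 2 (0.38 log units; beyond the scatter), was modest and is a swap on a carbonyl carbon, so it bears only indirectly and no measured step covers this change. The expected move, resting on that single step, is a 1.9-fold lower number from compound 2 to compound 3 (0.27 log units; within the scatter), a modest one to a lower number. For compound 3 the estimated value is 300000 nM, with an expected range of 100000 nM to 900000 nM.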

Compound 3, half-maximal cytotoxic concentration: > 1530000 nM
Compound 3: only a limit was reported (the forecaster's own chance of this, stated with the estimate: 15%); middle value at least 5.1-fold (0.70 log units) from the limit.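

In this assay, capping the hydroxy on this saturated carbon as ((thiophen-2-yl)carbonyl)oxy gives an at least 2.7-fold higher number from compound 2 to compound 3 (0.43 log units; beyond the scatter). Within the data shown here, this is the first reading at this oxygen, since the earlier step concerned only a swap on a carbonyl carbon, and it shows that a free hydroxy here is not needed for more compound to be tolerated. The reading for compound 3 is a limit, not a number: the limit of > 1530000 nM in this assay, at which 1 of the 3 values shown sits.

From the compounds shown here alone, the full size of this step remains open. So does whether a smaller acetyl ester or a methyl ether at this oxygen would move the number the same way.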